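The source may hold more compounds than are shown below. What is called first, only, known or untested is meant among the compounds shown, and "the series" means these compounds.

This study concerns a small set of compounds built on a shared core and tested in a functional assay on MCF7 cells (Homo sapiens) for inhibition, read by MTT assay, with a stated time of 48 h; a lower number here means a stronger inhibitor, a higher number a weaker inhibitor. Going by the values given here, compound 1 `COc1cccc2c1OCN(c1ccc3oc(-c4ccccc4)cc(=O)c3c1)C2` is the only member with a reported number: in this assay compound 1 gives 17000 nM, a weak result. Compound 2 `O=c1cc(-c2ccccc2)oc2cc(N3COc4c(cccc4[N+](=O)[O-])C3)ccc12` gave no number in this assay; compound 2 was reported as "not active" (no number reported). The same holds for compound 3 `O=c1cc(-c2ccccc2)oc2ccc(N3COc4c(Br)cc(Br)cc4C3)cc12`, which in this assay was reported as "not active" (no number reported). Among the entries with a number, compound 1 therefore stands alone, and the two other measured compounds offer no scale against which to place it.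

Compound 4 `O=c1cc(-c2ccccc2)oc2ccc(N3COc4c(cccc4[N+](=O)[O-])C3)cc12` differs from compound 1 in one respect: nitro in place of methoxy on an aromatic carbon. Among the compounds with values here, no pair of measured compounds shows what such a swap does on this core, so there is no measured step to lean on. What is known is that compound 1 is already weak and that compounds 2 and 3, each carrying different groups, were reported without any number at all. The expectation for compound 4 is a step of a 1.8-fold higher number from compound 1 to compound 4 (0.25 log units; within the scatter) toward weaker inhibition, or no change beyond the scatter. In this assay compound 4 is expected to give about 30000 nM, within a range from 10000 nM to 100000 nM, with a real chance that only a limit and no number is reported.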

Compound 4, half-maximal inhibitory concentration: 28400 nM
Compound 4: middle estimate off by 1.1-fold (0.02 log units), on the high side; low and high end bracket the measured number.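

In this assay, going by these compounds alone, placing nitro in place of methoxy on this aromatic carbon gives a 1.7-fold higher number from compound 1 to compound 4 (0.22 log units; within the scatter), the first measured step on the shared core. This step shows that the exchange, which brings three heavy atoms in place of two and adds a double bond outside the aromatic rings, does not separate the two compounds beyond the usual variation between repeated measurements. At this position, then, compound 4 keeps a measurable result, 28400 nM, that cannot be told apart from that of compound 1, although no measurement shown explains this outcome.

From the compounds shown here alone, because this is a single exchange at a single position, it remains open whether an amine, a carboxylic acid or a longer alkyl chain on the same aromatic carbon would give a result distinct from compound 1. Also open, going by these compounds, is whether any change elsewhere on the shared core, such as on the unfused phenyl ring, would bring a stronger inhibitor than the two compounds compared here.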